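Acylating the free amine of compound 3: an expected step

The compounds below may be only part of what the source reports. "The series", "measured", "known", "first", "only" and "open" are said of these compounds alone.

Compound 3 `CN(c1ccc(N)cc1OCc1ccccc1)S(C)(=O)=O` carries a free aromatic amine; in an assay on SK-BR-3 cells for inhibition of Aromatase (Homo sapiens) (on this read-out higher numbers stand for weaker inhibition and lower numbers for stronger inhibition), compound 3 gives 1100 nM. Of the two numbers available in this assay this one stands highest, yet the nearest of them, that of compound 1 `CN(c1ccc([N+](=O)[O-])cc1OCc1ccc(-c2ccccc2)cc1)S(C)(=O)=O`, which in this assay gives 650 nM, differs from it only within the scatter. Compound 2 `O=C(Nc1ccc([N+](=O)[O-])cc1OCc1ccccc1)c1ccc([N+](=O)[O-])cc1` gives in this assay only > 25000 nM, which is a limit of the assay and not a number (the limit of > 25000 nM in this assay, at which 1 of the 3 values shown sits). Compound 4 `CN(c1ccc(NC(=O)C2CCCCC2)cc1OCc1ccccc1)S(C)(=O)=O` differs from compound 3 in one place: cyclohexylcarbonyl in place of hydrogen on a nitrogen on an aromatic ring. Going by the values given here, no measured pair shows this change, so its size is open; a step within the scatter in this assay, if anything towards a slightly higher number, is expected. For compound 4 the estimate in this assay is 1500 nM, between 400 nM and 6000 nM, an expected step of a 1.4-fold higher number from compound 3 to compound 4 (0.13 log units; within the scatter).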

Compound 4, half-maximal inhibitory concentration: 250 nM
Compound 4: middle estimate off by 6.0-fold (0.78 log units), on the high side; the whole stated range lies above it.
By their numbers in this assay, from the lowest: compound 4; then compounds 1 and 3 (each within the scatter of the next). At a limit, above all of these: compound 2.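

Acylation of this nitrogen is more than tolerated: in this assay the cyclohexylcarbonyl group brings a 4.4-fold lower number from compound 3 to compound 4 (0.64 log units; beyond the scatter) and gives the only step beyond the scatter at this position. Going by these compounds alone, the free amine is therefore not needed for inhibition, at least in the one pair that can be read. No measurement shown bears on what lies behind this gain. From the compounds shown here alone, whether a smaller acetyl group, a longer open alkyl chain on the carbonyl or a cyclopentylcarbonyl group would do the same remains open.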